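The source may report more compounds than this note shows. Statements on the series, on what has been measured and on what is new or still open speak of the compounds shown alone.

Among the measured compounds shown here, compound 3, `CC(=O)c1ccc(-c2cn3ccnc3c(-c3ccc4ncn(C5CCCCC5)c4c3)n2)cc1`, is the lowest of the three compounds measured so far in a functional assay on SN12C cells (Homo sapiens) for inhibition, read by sulforhodamine B assay, with a stated time of 48 h, tested at 10 uM; on this read-out higher numbers stand for more inhibition at the one concentration tested (going by the name of the read-out) and lower numbers for less inhibition: compound 3 gives 6.33%. Its nearest neighbour is compound 2, `c1ccc2c(-c3cn4ccnc4c(-c4ccc5ncn(C6CCCCC6)c5c4)n3)cccc2c1`, which in this assay gives 11.7%, a gap that the step of a number 5.4 percentage points lower from compound 2 to compound 3 (within the scatter) shows to lie within the scatter. The furthest is compound 1, `O=Cc1ccc(-c2cn3ccnc3c(-c3ccc4ncn(C5CCCCC5)c4c3)n2)cc1`, which gives 20.7%; the step of a number 14.4 percentage points lower from compound 1 to compound 3 (beyond the scatter) is the only one of the three that goes beyond the scatter, and the remaining step, a number 9 percentage points lower from compound 1 to compound 2 (within the scatter), again stays within it.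

Compound 4, `Clc1ccc(-c2cn3ccnc3c(-c3ccc4ncn(C5CCCCC5)c4c3)n2)cc1`, differs from compound 3 in one place: chloro in place of acetyl on an aromatic carbon. For the measured compounds named here, no measured step swaps the acetyl for a chloro, so the expectation can rest only on the spread of the three numbers. Going by the values given here, the one step that touches the carbonyl, a number 14.4 percentage points lower from compound 1 to compound 3 (beyond the scatter), was modest, and the two steps that exchange the whole aryl group stayed within the scatter, so a small move, if any, is expected here. Compound 4 is therefore estimated to give 12% in this assay, between 0% and 28%, which means an expected step of a number 5.7 percentage points higher from compound 3 to compound 4 (within the scatter) that is not expected to clear the scatter.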

Compound 4, a percentage reported as inhibition, at one concentration (the size of the read-out at that concentration, not a potency): 13.5%
Compound 4: middle estimate off by 1.5 percentage points, on the low side, and the stated range covers the measured number.
By their numbers in this assay, from the lowest: compounds 3, 2, 4 and 1 (each within the scatter of the next, the first and the last beyond it).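

In this assay, exchanging the acetyl, with its carbonyl and three heavy atoms, for the single chlorine atom of chloro at this place, para to a large group, gives a number 7.2 percentage points higher from compound 3 to compound 4 (within the scatter), so removing the hydrogen-bond acceptor and shortening the group leaves the read-out within the scatter. The chloro group also stays within the scatter of the other two aryl groups, with a number 7.2 percentage points lower from compound 1 to compound 4 (within the scatter) and a number 1.8 percentage points higher from compound 2 to compound 4 (within the scatter), so compound 4 sits within the scatter of every earlier compound and the step from compound 1 to compound 3 remains the only one beyond it. The compounds shown offer no measurement that could explain these small differences.

What the four compounds leave open is whether any group at this place can move the read-out clearly beyond the range seen so far, for instance an amine or a carboxylic acid on the same ring in place of chloro. Also open, from the compounds shown here alone, is how much the cyclohexyl group, which all four compounds share, contributes, since a smaller chain such as methyl in its place would be a change at a different part of the molecule.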